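Chloro for methoxy on an inactive trifluoromethyl core

A few compounds are considered here, and "the series" means these few. Any claim that something is new, unique, unknown or untested is made for them only; others in the source may bear on it.

Measured so far:
compound 1, `Cc1nc(-c2ccc(F)cc2)c(C(=O)N2CCN(c3cccc(Cl)c3)CC2)o1`, 40.1 nM in a functional assay on HL-60 cells (Homo sapiens) for inhibition, read by MTT assay, with a stated time of 72 h; on this read-out higher numbers stand for weaker inhibition and lower numbers for stronger inhibition
compound 2, `COc1cccc(N2CCN(C(=O)c3oc(C)nc3-c3ccc(F)cc3)CC2)c1`, 112 nM
compound 3, `COc1cccc(N2CCN(C(=O)c3oc(C(F)(F)F)nc3-c3ccc(F)cc3)CC2)c1`, recorded as "not active" (no number reported), with no number given

Compound 1 and compound 2 share one core and differ only at the outer ring: chloro in place of methoxy on an aromatic carbon. That single swap gave a 2.8-fold lower number from compound 2 to compound 1 (0.45 log units; beyond the scatter). Compound 3 is built on a different core; how it differs from compound 2 is trifluoromethyl in place of methyl on an aromatic carbon. With that core, compound 3 was reported in this assay as not active, so no number stands against it.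

Compound 4, `O=C(c1oc(C(F)(F)F)nc1-c1ccc(F)cc1)N1CCN(c2cccc(Cl)c2)CC1`, is not yet measured. It carries the core of compound 3 and differs from compound 3 by chloro in place of methoxy on an aromatic carbon. This is the same change that separates compound 2 from compound 1, and it sits at the same place, so the step is expected to be of a similar modest size, resting on a 2.8-fold lower number from compound 2 to compound 1 (0.45 log units; beyond the scatter). Because compound 3 is recorded as "not active" (no number reported) and gave no number at all, a modest step of that size is not expected to bring compound 4 into the range where compound 1 and compound 2 stand.

Compound 4 is therefore estimated at 15000 nM in this assay, with an expected range from 3000 nM to 80000 nM, and a real chance that only a limit and no number is reported.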

Compound 4, half-maximal inhibitory concentration: "not active" (no number reported)
The entry for compound 4 holds no number; there is nothing to compare the estimate with.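

Compound 3 and compound 4 are both recorded as not active in this assay, with no number for either, so no step can be read from the swap of methoxy for chloro on this core. Nothing measured here bears on why the trifluoromethyl core gives no number. The compounds shown leave open how far the activity of compound 3 and compound 4 lies from that of compound 1 and compound 2.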